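The source may report more compounds than this note shows. Statements on the series, on what has been measured and on what is new or still open speak of the compounds shown alone.

Measured compounds:
Compound 1, `CC(=O)Cn1cc(CNC(=O)c2cnc(Nc3ccc(C#N)cc3)cc2Oc2c(C)cc(C)cc2C)nn1`: in an ADME assay on MT4 cells (Homo sapiens) for cytotoxicity, read by MTT assay, with a stated time of 5 days (on this read-out lower numbers stand for higher toxicity in this test and higher numbers for lower toxicity in this test), compound 1 gives 19400 nM.
Compound 2, `Cc1cc(C)c(Oc2cc(Nc3ccc(C#N)cc3)ncc2C(=O)NCc2cn(Cc3ccc(Cl)cc3)nn2)c(C)c1`: in this assay compound 2 gives >= 120000 nM, which is a limit of the assay rather than a number.

Compound 2 therefore stands at the upper end of what this assay can report, as described by the limit of >= 120000 nM in this assay, at which 1 of the 2 values shown sits. For the measured compounds named here, the only step known here is an at least 6.1-fold higher number from compound 1 to compound 2 (0.79 log units; beyond the scatter), and it ends at that limit.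

Compound 3, `Cc1cc(C)c(Oc2cc(Nc3ccc(C#N)cc3)ncc2C(=O)NCc2cn(Cc3ccccc3C)nn2)c(C)c1`, is not yet measured. It differs from compound 2 by 2-methylphenyl in place of 4-chlorophenyl on a saturated chain carbon bound to an aromatic nitrogen. Going by the values given here, no measured step concerns a change from one aryl group to another on this chain carbon, so the step 1>2 offers only indirect guidance: it shows that an aromatic group at this position sits beyond the assay ceiling, while the change to compound 3 keeps an aromatic group there. The expected step of a number no higher from compound 2 to compound 3 (the limit leaves the size open) is therefore none beyond the scatter. Compound 3 is estimated at 120000 nM in this assay, with a range from 40000 nM to 300000 nM, and most likely again only a limit.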

Compound 3, half-maximal cytotoxic concentration: >= 164000 nM
Compound 3: a limit, no number (the forecaster's own chance of this, stated with the estimate: 70%); at least 1.3-fold (0.13 log units) between middle value and limit.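

In this assay compound 3 gives >= 164000 nM, which is a limit of the assay and not a number. Putting 2-methylphenyl in place of acetyl on the saturated chain carbon bound to an aromatic nitrogen gives an at least 8.4-fold higher number from compound 1 to compound 3 (0.92 log units; beyond the scatter), so the rise seen earlier with 4-chlorophenyl is no longer a single case: two different aromatic groups at this place now read higher than acetyl, and on this read-out a higher number stands for lower toxicity in this test. The step from 4-chlorophenyl to 2-methylphenyl itself cannot be read, so these compounds give no order for the two groups, and swapping the one for the other has not brought the number down from the limit of the assay.

The compounds shown leave open whether a ring is needed at this place at all, since only acetyl stands for the groups without one, and a longer chain, an amine or a carboxylic acid could read quite differently. They also cannot separate the two aromatic groups, and a plain phenyl would not settle that while the values stay at limits.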